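Swapping pyridin-4-yl for phenyl: what compound 4 might give

The source may hold more compounds than are shown below. What is called first, only, known or untested is meant among the compounds shown, and "the series" means these compounds.

Measured so far in a functional assay on KG-1 cells (Homo sapiens) for cytotoxicity, read by luminescence and CellTiter-Glo, with a stated time of 3 days; a higher number here means a weaker inhibitor, a lower number a stronger inhibitor:
compound 1 `Cc1ccc(C(=O)Nc2ccc(C#N)cc2)c(O)c1` gives 2560 nM
compound 2 `N#Cc1ccc(NC(=O)c2ccc(C(F)(F)F)cc2O)cc1` gives 1440 nM
compound 3 `N#Cc1ccc(NC(=O)c2ccc(-c3ccncc3)cc2O)cc1` gives 8840 nM

Compound 3 stands highest of the three numbers in this assay. Its nearest neighbour is compound 1, reached by a 3.5-fold higher number from compound 1 to compound 3 (0.54 log units; beyond the scatter); the furthest is compound 2, reached by a 6.1-fold higher number from compound 2 to compound 3 (0.79 log units; beyond the scatter). Both steps put pyridin-4-yl onto the shared core in place of a smaller group and both raised the number beyond the scatter.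

Compound 4 `N#Cc1ccc(NC(=O)c2ccc(-c3ccccc3)cc2O)cc1` differs from compound 3 in one place: phenyl in place of pyridin-4-yl on an aromatic carbon.

Within the data shown here, no measured step replaces pyridin-4-yl with phenyl, so the two steps into compound 3 bear only indirectly. They show that a change at this aromatic carbon can move the number well beyond the scatter, and that the group leaving here is the one whose arrival raised it. A phenyl of the same size is therefore expected to give a modestly lower number, though a result within the scatter would not surprise. The estimate for compound 4 in this assay is 4500 nM, between 1500 nM and 12000 nM, meaning a step of a 2.0-fold lower number from compound 3 to compound 4 (0.29 log units; within the scatter) is expected.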

Compound 4, half-maximal inhibitory concentration: 410 nM
Beside the measured number, compound 4's estimate is 11-fold (1.04 log units) above it, outside the stated range (below it).
By their numbers in this assay, from the lowest: compound 4; then compounds 2 and 1 (each within the scatter of the next); then compound 3.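

In this assay, the exchange of ring nitrogen for carbon, which leaves the size of the group unchanged, gives a 22-fold lower number from compound 3 to compound 4 (1.33 log units; beyond the scatter) and so shows that this position responds strongly to more than the size of the group placed there. Phenyl also gives a 3.5-fold lower number from compound 2 to compound 4 (0.55 log units; beyond the scatter) and a 6.2-fold lower number from compound 1 to compound 4 (0.80 log units; beyond the scatter), so a six-membered aromatic ring here does not in itself raise the number, and compound 4 has the lowest number of the series, with compound 3 the one ring-bearing compound that goes the other way. No measurement shown explains the gap between the two rings.

The compounds shown leave open whether moving the ring nitrogen, as in pyridin-3-yl, would give a number nearer that of compound 3 or compound 4. They also leave open how a phenyl carrying an amine or a carboxylic acid would behave at this position.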